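The source may hold more compounds than are shown below. What is called first, only, known or untested is meant among the compounds shown, and "the series" means these compounds.

In a functional assay on OVCAR-3 cells (Homo sapiens) for antiproliferative activity, read by spectrophotometry, with a stated time of 2 days (a lower number here means a stronger inhibitor of growth, a higher number a weaker inhibitor of growth), compound 1 (`CC(=O)N1CCN(c2ccc(Nc3ncc(C(F)(F)F)c(N4Cc5cccc(N(C)S(C)(=O)=O)c5C4)n3)cc2)CC1`) gives 970 nM and compound 2 (`COc1cc(N2CCN(C(C)=O)CC2)ccc1Nc1ncc(C(F)(F)F)c(N2Cc3cccc(N(C)S(C)(=O)=O)c3C2)n1`) gives 1600 nM, so the two stand level within the scatter. Compound 3 (`CN(c1cccc2c1CN(c1nc(Nc3ccc(Nc4ccccc4)cc3)ncc1C(F)(F)F)C2)S(C)(=O)=O`) differs from compound 1 by anilino in place of 4-acetylpiperazin-1-yl on an aromatic carbon, with anilino in place of 4-acetylpiperazin-1-yl. Going by the values given here, the only measured step, a 1.6-fold higher number from compound 1 to compound 2 (0.22 log units; within the scatter), comes from methoxy in place of hydrogen on an aromatic carbon, and no measured step covers the new exchange. Nothing therefore supports an expected shift beyond the scatter in this assay. The expected change is a 1.5-fold higher number from compound 1 to compound 3 (0.19 log units; within the scatter). For compound 3 the estimated value is 1500 nM, with an expected range from 400 nM to 6000 nM.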

Compound 3, concentration for 50% growth inhibition: > 50000 nM
Compound 3: only a limit was reported; the forecaster's own chance of this, stated with the estimate: 8%; middle value at least 33-fold (1.52 log units) away from the limit.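

In this assay, going by these compounds alone, anilino in place of 4-acetylpiperazin-1-yl on this aromatic carbon, para to a large group, gives an at least 51-fold higher number from compound 1 to compound 3 (1.71 log units; beyond the scatter), the first step here that lies beyond the scatter. This carbon's substituent therefore matters to growth inhibition, and 4-acetylpiperazin-1-yl cannot be exchanged for anilino without a large weakening. The value of compound 3 is a limit: the limit of > 50000 nM in this assay, at which 1 of the 3 values shown sits.

The compounds shown leave open whether the step follows from the entering anilino or from the departing 4-acetylpiperazin-1-yl. A morpholine or a free piperazine on the same carbon would bear on that question.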